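Swapping a carboxyphenyl for a tetrazolylphenyl on the amine

The source may report more compounds than this note shows. Statements on the series, on what has been measured and on what is new or still open speak of the compounds shown alone.

Three measured compounds share one core and differ only in the group attached to a saturated chain carbon bound to an amine nitrogen in a ring: compound 1 `Clc1cc(Cl)cc(CO[C@H]2CCCN(Cc3ncco3)[C@H]2c2ccccc2)c1`, compound 2 `Clc1cc(Cl)cc(CO[C@H]2CCCN(Cc3nccs3)[C@H]2c2ccccc2)c1` and compound 3 `COc1ccc(C(=O)O)cc1CN1CCC[C@H](OCc2cc(Cl)cc(Cl)c2)[C@@H]1c1ccccc1`. In an assay on isolated protein for activation of cGMP-dependent protein kinase 1 (Homo sapiens), read by ADP-Glo, with stated times of 120 min and 40 min (on this read-out lower numbers stand for an effect already at smaller amounts and higher numbers for an effect only at larger amounts of compound), compound 1 gives only a limit, > 200000 nM. In this assay compound 2 also gives only a limit, > 200000 nM. For the measured compounds named here, compound 3 is the one compound with a real number in this assay, 123000 nM, and so it is the only fixed point among the three. The step that the two limits leave unreadable from compound 1 to compound 2 is unreadable. The steps of an at least 1.6-fold lower number from compound 1 to compound 3 (0.21 log units; that floor lies within the scatter) and an at least 1.6-fold lower number from compound 2 to compound 3 (0.21 log units; that floor lies within the scatter) set only a floor (the limit of > 200000 nM in this assay, at which 2 of the 3 values shown sit).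

Compound 4 `Clc1cc(Cl)cc(CO[C@H]2CCCN(Cc3ccc(-c4nn[nH]n4)cc3)[C@H]2c2ccccc2)c1` changes the group on that same carbon: 4-(2H-tetrazol-5-yl)phenyl in place of 5-carboxy-2-methoxyphenyl on a saturated chain carbon bound to an amine nitrogen in a ring. Going by the values given here, no measured step concerns this particular exchange; the readable steps describe the entry of the carboxy-bearing group in place of small five-membered rings, and their floors lie within the scatter. Therefore no direction beyond the scatter is expected in this assay for compound 4, with a step of a 1.1-fold lower number from compound 3 to compound 4 (0.05 log units; within the scatter) estimated. Compound 4 is expected to give about 110000 nM, with a range from 30000 nM to 300000 nM.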

Compound 4, half-maximal effective concentration: 74000 nM
Compound 4: middle estimate off by 1.5-fold (0.17 log units), on the high side; measured number inside the range.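

In this assay, placing 4-(2H-tetrazol-5-yl)phenyl instead of 5-carboxy-2-methoxyphenyl on the saturated chain carbon bound to an amine nitrogen in a ring gives a 1.7-fold lower number from compound 3 to compound 4 (0.22 log units; within the scatter), so this assay cannot tell these two groups apart. For the compounds shown here, measured against the small five-membered rings, the tetrazole-bearing group gives an at least 2.7-fold lower number from compound 2 to compound 4 (0.43 log units; beyond the scatter) and an at least 2.7-fold lower number from compound 1 to compound 4 (0.43 log units; beyond the scatter), the first steps at this position that clear the usual scatter, which the steps to compound 3 did not do. Both are only floors, and their true sizes stay hidden because compound 1 and compound 2 each give a limit rather than a number: the limit of > 200000 nM in this assay, at which 2 of the 4 values shown sit.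

The exchange from compound 3 to compound 4 removes a methoxy group along with the carboxylic acid and brings in the tetrazole, so a phenyl carrying only a carboxylic acid would be needed to separate those changes. On these data alone, it also remains open how a plain phenyl, or a phenyl carrying an amine or a sulfonamide, would read at this position.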